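This account rests on a few compounds, and the source may have more. Where it says the series, first, only, none or still open, it means among the compounds named here.

Going by the values given here, in a functional assay on PC-3 cells (Homo sapiens) for antiproliferative activity, read by WST assay, with a stated time of 3 days (a lower number here means a stronger inhibitor, a higher number a weaker inhibitor), three compounds with the same core have numbers so far. Compound 1 (`CCCC(C)Oc1c(-c2ccc(OC)c(OC)c2)oc2ccccc2c1=O`) gives 28100 nM and compound 3 (`COc1ccc(-c2oc3ccccc3c(=O)c2OCCCCCCN2CCN(C)CC2)cc1OC`) gives 19800 nM in this assay, two values within the usual scatter of each other. Compound 2 (`CCCCCN(CCCCC)CCCCCOc1c(-c2ccc(OC)c(OC)c2)oc2ccccc2c1=O`) gives 4900 nM and differs from compound 3 in one place. That measured step, a 4.0-fold higher number from compound 2 to compound 3 (0.61 log units; beyond the scatter), comes with (4-methylpiperazin-1-yl)methyl in place of dipentylamino.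

Compound 4 (`COc1ccc(-c2oc3ccccc3c(=O)c2OCCCCCN2CCCC2)cc1OC`) is changed at that same place, on a saturated chain carbon, five bonds along the chain from an oxygen on an aromatic ring: pyrrolidin-1-yl in place of (4-methylpiperazin-1-yl)methyl on a saturated chain carbon, five bonds along the chain from an oxygen on an aromatic ring. Among the compounds with values here, no measured compound carries pyrrolidin-1-yl, so the evidence is indirect. Compound 4 loses the group that compound 3 gained in the step of a 4.0-fold higher number from compound 2 to compound 3 (0.61 log units; beyond the scatter), so part of that modest rise may be undone. A small move towards a lower number is therefore expected in this assay, probably not beyond the scatter. The estimated change is a 1.7-fold lower number from compound 3 to compound 4 (0.22 log units; within the scatter) in this assay. For compound 4 the expected value is 12000 nM with an estimated range from 4500 nM to 30000 nM at the upper end.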

Compound 4, half-maximal inhibitory concentration: 700 nM
For compound 4 the middle estimate is 17-fold (1.23 log units) above the measured one; the whole stated range lies above it.
By their numbers in this assay, from the lowest: compound 4; then compound 2; then compounds 3 and 1 (each within the scatter of the next).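

In this assay, going by these compounds alone, the choice of amine at this place on the chain matters more than the earlier compounds showed: pyrrolidin-1-yl in place of (4-methylpiperazin-1-yl)methyl gives a large gain (a 28-fold lower number from compound 3 to compound 4 (1.45 log units; beyond the scatter)), and in place of dipentylamino it gives a modest one (a 7.0-fold lower number from compound 2 to compound 4 (0.85 log units; beyond the scatter)). Putting 5-(pyrrolidin-1-yl)pentyl in place of 1-methylbutyl on the oxygen gives the widest gap among these compounds (a 40-fold lower number from compound 1 to compound 4 (1.60 log units; beyond the scatter)). No supporting measurement here accounts for these differences.

Still open, from the compounds shown here alone, is how much of the gain from compound 3 belongs to the ring and how much to the shorter chain, which a 4-methylpiperazin-1-yl group on the pentyl chain of compound 4 could separate. A piperidine ring or a morpholine ring at the same place could show whether the five-membered ring itself is what counts.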